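Chloro step from compound 1 in microsomal clearance

The source may report more compounds than this note shows. Statements on the series, on what has been measured and on what is new or still open speak of the compounds shown alone.

Measured so far:
compound 1 `Nc1ccc(S(=O)(=O)c2ccc(-c3ccc(C(O)(C(F)(F)F)C(F)(F)F)cn3)cc2)cn1`: < 14 mL.min-1.g-1
compound 2 `Nc1ccc(S(=O)(=O)c2ccc(-c3ncc(C(O)(C(F)(F)F)C(F)(F)F)cn3)cc2)cn1`: < 14 mL.min-1.g-1

In an ADME assay (liver) for metabolic stability, with Liver microsome (Rattus norvegicus) as the target, using microsomes and NADPH, with a stated time of 30 min, at 37 degrees C, tested at 1 uM (a lower number here means slower removal, a higher number faster removal of the compound), compound 1 gives < 14 mL.min-1.g-1, which is a limit and not a number. Compound 2 gives < 14 mL.min-1.g-1, also a limit. Within the data shown here, both compounds stand at the limit of < 14 mL.min-1.g-1 in this assay, at which 2 of the 2 values shown sit, so no measured step is available.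

Compound 3 `Nc1ccc(S(=O)(=O)c2ccc(-c3ncc(C(O)(C(F)(F)F)C(F)(F)F)cc3Cl)cc2)cn1` differs from compound 1 by one change: chloro in place of hydrogen on an aromatic carbon. In this assay no change beyond the scatter is expected. The expected step is a step that the limit leaves unreadable from compound 1 to compound 3. For compound 3 the estimate is 12 mL.min-1.g-1, with an expected range of 7 mL.min-1.g-1 to 25 mL.min-1.g-1.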

Compound 3, intrinsic clearance in microsomes: 18 mL.min-1.g-1
Estimate against measurement, compound 3: 1.5-fold (0.18 log units) below; measured number inside the range.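

In this assay, chloro on this aromatic carbon, ortho to a large group and two atoms from the ring nitrogen, yields a measured number: compound 3 gives 18 mL.min-1.g-1. The step is an at least 1.2-fold higher number from compound 1 to compound 3 (0.10 log units; that floor lies within the scatter), so this change cannot be said to shift clearance beyond the scatter. The other values shown remain a limit of the assay: the limit of < 14 mL.min-1.g-1 in this assay, at which 2 of the 3 values shown sit.

As far as these compounds go, the true size of the step remains open, since its floor rests on a limit. Also open, from the compounds shown here alone, is how a fluoro, methyl or nitrile group would read on this same carbon.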